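Hydrogen for bromo on the aryl group of compound 2

The source may report more compounds than this note shows. Statements on the series, on what has been measured and on what is new or still open speak of the compounds shown alone.

In a functional assay on cells (Panel NCI-60 (60 carcinoma cell lines), Homo sapiens) for inhibition, read by colorimetric assay, with a stated time of 3 days (on this read-out lower numbers stand for stronger inhibition of growth and higher numbers for weaker inhibition of growth), compound 2 `O=C(CCCCCCNC(=O)C(O)(O)C(F)(F)F)Nc1ncc(-c2ccc(Br)cc2)s1` gives 930 nM. Compound 1 `COc1ccc(-c2cnc(NC(=O)CCCCCCNC(=O)C(O)(O)C(F)(F)F)s2)cc1` gives 1000 nM, which lies within the scatter of the value for compound 2. Compound 3 `O=C(CCCCCCNC(=O)C(O)(O)C(F)(F)F)Nc1ccc(Br)cc1` gives 3160 nM, a higher number than compound 2 shows and beyond the scatter from it.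

The next structure is compound 4 `O=C(CCCCCCNC(=O)C(O)(O)C(F)(F)F)Nc1ncc(-c2ccccc2)s1`, which differs from compound 2 as follows: hydrogen in place of bromo on an aromatic carbon. In words, this is hydrogen in place of bromo on an aromatic carbon, or 4-bromophenyl to phenyl.

Among the compounds with values here, one measured step bears on this carbon: a 1.1-fold lower number from compound 1 to compound 2 (0.03 log units; within the scatter), with bromo in place of methoxy. That exchange left the number unchanged within the scatter. Within the data shown here, no measured compound yet carries hydrogen at this carbon, so the evidence is indirect. Compound 3 differs from compound 2 in more than this one group and gives no clean guide to the change.

No step beyond the scatter is therefore expected in this assay, and no direction is favoured. The expected step is a 1.1-fold higher number from compound 2 to compound 4 (0.03 log units; within the scatter). For compound 4 the estimate is 1000 nM, with an expected range of 500 nM to 2000 nM.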

Compound 4, concentration for 50% growth inhibition: 3020 nM
Compound 4: middle estimate off by 3.0-fold (0.48 log units), on the low side, outside the stated range (above it).
By their numbers in this assay, from the lowest: compounds 2 and 1 (each within the scatter of the next); then compounds 4 and 3 (each within the scatter of the next).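

In this assay, the bare carbon separates from both substituted compounds: 4-bromophenyl to phenyl gives a 3.2-fold higher number from compound 2 to compound 4 (0.51 log units; beyond the scatter), and hydrogen in place of methoxy gives a 3.0-fold higher number from compound 1 to compound 4 (0.48 log units; beyond the scatter). The exchange of methoxy for bromo had shown only that these two groups cannot be told apart here; the hydrogen compound now shows that the group on this aromatic carbon, para to a large group, is not indifferent to growth inhibition, with compound 1 and compound 2 both giving stronger inhibition than compound 4. No measurement shown gives a reason for this loss on going to hydrogen, so the finding remains a description of compound 1, compound 2 and compound 4.

From the compounds shown here alone, two substituents are a narrow basis, so it stays open whether an amine, a carboxylic acid, a fluoro or a methyl group at this carbon would match bromo and methoxy or fall nearer to hydrogen. It is equally open whether steps of this size would hold with a longer chain or a shorter chain in place of the present one, since all the compounds shown share the same chain.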